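This account rests on a few compounds, and the source may have more. Where it says the series, first, only, none or still open, it means among the compounds named here.

In a functional assay on HEK293 cells (Homo sapiens) for cytotoxicity, read by MTT assay, with a stated time of 48 h (a lower number here means that less compound is tolerated, a higher number that more compound is tolerated), compound 1 `C=C1CC[C@@H]2[C@](C)(CO)[C@H](O)CC[C@@]2(C)[C@@H]1C/C=C1/C(=O)OC[C@H]1OC(=O)CCl` gives 20000 nM and compound 2 `C=C1CC[C@@H]2[C@](C)(CO)[C@H](O)CC[C@@]2(C)[C@@H]1C/C=C1/C(=O)OC[C@H]1OC(=O)CBr` gives 12000 nM so far, two numbers that lie within the usual scatter of each other. Compound 3 `C=C1CC[C@@H]2[C@](C)(CO)[C@H](O)CC[C@@]2(C)[C@@H]1C/C=C1/C(=O)OC[C@H]1OC(=O)CI` is still unmeasured and carries iodo in place of bromo on a saturated chain carbon bound to a carbonyl carbon. Among the compounds with values here, the only measured step that bears on this is the swap of chloro for bromo at that same place (a 1.7-fold lower number from compound 1 to compound 2 (0.22 log units; within the scatter)), which stays within the scatter. No step beyond the scatter is therefore expected in this assay, only perhaps a slight one in the same direction. The expected change is small (a 1.3-fold lower number from compound 2 to compound 3 (0.12 log units; within the scatter)). The estimated value for compound 3 is 9000 nM (expected range 3500 nM to 20000 nM).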

Compound 3, concentration lethal to 50% of the cells: 8000 nM
Estimate against measurement, compound 3: 1.1-fold (0.05 log units) above, within the range that was stated.
By their numbers in this assay, from the lowest: compounds 3, 2 and 1 (each within the scatter of the next, the first and the last beyond it).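

Iodo in place of bromo gives a 1.5-fold lower number from compound 2 to compound 3 (0.18 log units; within the scatter) in this assay, so this swap alone cannot be told apart from repeated measurement. Iodo in place of chloro at the same saturated chain carbon gives a 2.5-fold lower number from compound 1 to compound 3 (0.40 log units; beyond the scatter), the first step at this position to pass the scatter, though only between the chloro and iodo compounds. Nothing measured here explains this difference.

Open, from the compounds shown here alone, is how a non-halogen group, such as an amine or a hydroxyl, would read at this place.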